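Amide substituent changes on a piperazine-linked aminomethyl series

The compounds below may be only part of what the source reports. "The series", "measured", "known", "first", "only" and "open" are said of these compounds alone.

Measured so far in an assay on HEK293 cells for displacement of a labelled ligand from Melanocortin receptor 4 (Homo sapiens); a higher number here means a weaker inhibitor, a lower number a stronger inhibitor:
compound 1 `Cc1ccc(CC(C)C(=O)N2CCN(c3ccc(C(F)(F)F)cc3[C@@H](N)CC(C)C)CC2)cc1C` gives 240 nM
compound 2 `CC(C)C[C@H](N)c1cc(C(F)(F)F)ccc1N1CCN(C(=O)CNc2ccccc2)CC1` gives 3600 nM
compound 3 `COc1cc(CC(C)C(=O)N2CCN(c3ccc(C(F)(F)F)cc3[C@@H](N)CC(C)C)CC2)ccc1Cl` gives 230 nM

Compound 3 has the lowest number of the three in this assay, but its gap to compound 1 is within the scatter (a 1.0-fold lower number from compound 1 to compound 3 (0.02 log units; within the scatter)). Compound 4 `CC(C)C[C@H](N)c1cc(C(F)(F)F)ccc1N1CCN(C(=O)CCC(=O)c2ccc(Cl)cc2)CC1` is the next change: 2-((4-chlorophenyl)carbonyl)ethyl in place of 1-(4-chloro-3-methoxybenzyl)ethyl on a carbonyl carbon. Going by the values given here, the steps that bear on it replace the whole group on the carbonyl carbon: a 15-fold higher number from compound 1 to compound 2 (1.18 log units; beyond the scatter) and a 16-fold lower number from compound 2 to compound 3 (1.19 log units; beyond the scatter), both large. Compound 4 keeps an aromatic ring on that side but with a different chain, so a moderate weakening is expected, a 2.6-fold higher number from compound 3 to compound 4 (0.42 log units; beyond the scatter). Compound 4 is estimated at 600 nM, with a range from 200 nM to 2500 nM.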

Compound 4, inhibition constant: 820 nM
The estimate for compound 4 lay 1.4-fold (0.14 log units) below the measured number; low and high end bracket the measured number.
By their numbers in this assay, from the lowest: compounds 3 and 1 (each within the scatter of the next); then compound 4; then compound 2.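

In this assay, 2-((4-chlorophenyl)carbonyl)ethyl on the carbonyl carbon gives a 3.6-fold higher number from compound 3 to compound 4 (0.55 log units; beyond the scatter) and a 3.4-fold higher number from compound 1 to compound 4 (0.53 log units; beyond the scatter) but also a 4.4-fold lower number from compound 2 to compound 4 (0.64 log units; beyond the scatter) and all three steps are modest. This position therefore supports an intermediate level as well as the two levels seen earlier, and an aromatic ring in the group does not alone set the number. No measurement shown explains these steps.

As far as these compounds go, whether a hydroxyl in place of the chain carbonyl of compound 4 or a longer chain would shift the number remains open.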